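This account rests on a few compounds, and the source may have more. Where it says the series, first, only, none or still open, it means among the compounds named here.

The measured compounds and their read-outs in a functional assay on a cell-free system (plasma, Oryctolagus cuniculus) for inhibition of platelet-activating factor acetylhydrolase (Homo sapiens), tested at 100 nM; on this read-out higher numbers stand for more inhibition at the one concentration tested (going by the name of the read-out) and lower numbers for less inhibition:
compound 1 `CCCCCCCCN(C)C(=O)Cn1cc(Cc2cnc(O)nc2)c(=O)nc1SCc1ccc(F)cc1`, 34%
compound 2 `CCCCCCCCN(C)C(=O)Cn1cc(Cc2cnc(=O)n(C)c2)c(=O)nc1SCc1ccc(F)cc1`, 19%
compound 3 `CCCCCCCCCCCCN(C)C(=O)Cn1cc(Cc2cnc(O)nc2)c(=O)nc1SCc1ccc(F)cc1`, 39%

Among these three numbers compound 3 stands highest in this assay. Its nearest neighbour is compound 1, and that gap lies within the usual scatter, so the two cannot be told apart; compound 2 lies furthest off, and that gap is beyond the scatter. All three share one core and differ in two places only: the chain on the amide-type nitrogen, and the ring on the saturated chain carbon bound to an aromatic carbon.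

Compound 4 `CCCCCCCCCCCCN(C)C(=O)Cn1cc(Cc2cnc(=O)n(C)c2)c(=O)nc1SCc1ccc(F)cc1` has not yet been measured. Relative to compound 3 the change is a group of 8 heavy atoms (5 carbon, 2 nitrogen, 1 oxygen; one six-membered aromatic ring with 2 hetero atoms) in place of a group of 7 heavy atoms (4 carbon, 2 nitrogen, 1 oxygen; one six-membered aromatic ring with 2 hetero atoms), on a saturated chain carbon bound to an aromatic carbon. The chain stays as in compound 3.

Going by the values given here, one measured step bears directly on this: the same ring exchange, on the shorter chain, gave a number 15 percentage points lower from compound 1 to compound 2 (beyond the scatter). The other step, a number 5 percentage points higher from compound 1 to compound 3 (within the scatter), shows that the chain on its own moves the read-out by no more than the scatter. A change of similar size and direction is therefore expected here, estimated as a number 15 percentage points lower from compound 3 to compound 4 (beyond the scatter). For compound 4 the estimated value in this assay is 24%, with a likely range from 12% to 36%.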

Compound 4, a percentage reported as inhibition, at one concentration (the size of the read-out at that concentration, not a potency): 32%
Estimate against measurement, compound 4: 8 percentage points below; low and high end bracket the measured number.
By their numbers in this assay, from the lowest: compound 2; then compounds 4, 1 and 3 (each within the scatter of the next).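

In this assay, replacing the 2-hydroxypyrimidin-5-yl group with the group that has no hydrogen-bond donor gives a number 7 percentage points lower from compound 3 to compound 4 (within the scatter), so on the longer chain this exchange cannot be told from no change. The exchange nevertheless cannot be shown to differ in size between the two chains: the same change on two cores in this assay, a number 15 percentage points lower (beyond the scatter) from compound 1 to compound 2 and a number 7 percentage points lower (within the scatter) from compound 3 to compound 4, 8 percentage points apart, within the scatter of two such steps. Adding butyl to the chain gives a number 13 percentage points higher from compound 2 to compound 4 (beyond the scatter), a step beyond the scatter where the earlier one was not, yet these two steps cannot be told apart either: the same change on two cores in this assay, a number 5 percentage points higher (within the scatter) from compound 1 to compound 3 and a number 13 percentage points higher (beyond the scatter) from compound 2 to compound 4, 8 percentage points apart, within the scatter of two such steps.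

The compounds shown carry only two groups on this saturated chain carbon, so it remains open how an amine or a carboxylic acid there would read out. From the compounds shown here alone, it also remains open whether a chain longer than that of compound 3 would change the read-out further.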